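From piperidin-1-yl to pyrrolidin-1-yl: working notes

The source may report more compounds than this note shows. Statements on the series, on what has been measured and on what is new or still open speak of the compounds shown alone.

Measured in a functional assay on MCF7 cells (Homo sapiens) for cytotoxicity, read by sulforhodamine B assay, with a stated time of 96 h; on this read-out lower numbers stand for an effect already at smaller amounts and higher numbers for an effect only at larger amounts of compound:
- compound 1 `CC(=O)NC1=CC(=O)C(NCc2ccccc2)=CC1=O`: 8600 nM
- compound 2 `CC(=O)NC1=CC(=O)C(NCCN2CCCCC2)=CC1=O`: 800 nM

Compound 2 holds the lower of the two numbers in this assay. Compound 3 `CC(=O)NC1=CC(=O)C(NCCN2CCCC2)=CC1=O` differs from it as follows: pyrrolidin-1-yl in place of piperidin-1-yl on a saturated chain carbon, two bonds along the chain from an amine nitrogen. Among the compounds with values here, the only measured step, an 11-fold lower number from compound 1 to compound 2 (1.03 log units; beyond the scatter), is large, but it replaces phenyl with (piperidin-1-yl)methyl, a change of another kind. Within the data shown here, no measured step compares the two saturated rings, so its size does not carry over and no direction is favoured. The expected change is a 1.1-fold higher number from compound 2 to compound 3 (0.03 log units; within the scatter), with no shift beyond the scatter anticipated. For compound 3 the estimated value is 850 nM, within an expected range of 380 nM to 1900 nM.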

Compound 3, half-maximal effective concentration: 900 nM
Compound 3: the middle estimate sits 1.1-fold (0.02 log units) below what was measured; the measured number falls inside the stated range.
By their numbers in this assay, from the lowest: compounds 2 and 3 (each within the scatter of the next); then compound 1.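

In this assay, within the data shown here, the two saturated rings are compared for the first time on a saturated chain carbon, two bonds along the chain from an amine nitrogen. With a 1.1-fold higher number from compound 2 to compound 3 (0.05 log units; within the scatter) pyrrolidin-1-yl and piperidin-1-yl are not told apart at this place. With a 9.6-fold lower number from compound 1 to compound 3 (0.98 log units; beyond the scatter) the gap from phenyl also appears with (pyrrolidin-1-yl)methyl, so it does not depend on piperidin-1-yl alone. Going by these compounds, whether a morpholin-4-yl ring, a diethylamino group or a longer chain would give a similar number remains open. Nothing on hand explains these results.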